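From a benzyloxycarbonyl arm to a cyanomethyl arm

The source may report more compounds than this note shows. Statements on the series, on what has been measured and on what is new or still open speak of the compounds shown alone.

Compound 1 `CCOC(=O)Cn1c(=O)c(-c2ccc(OC)cc2)cc2c(OC)cc(OC)cc21`, compound 2 `CCN(CC)C(=O)Cn1c(=O)c(-c2ccc(OC)cc2)cc2c(OC)cc(OC)cc21` and compound 3 `COc1ccc(-c2cc3c(OC)cc(OC)cc3n(CC(=O)OCc3ccccc3)c2=O)cc1` share one core and differ only in the group on the carbonyl of their side chain. In a functional assay on LoVo cells (Homo sapiens) for cytotoxicity, read by colorimetric assay and MTT assay (on this read-out higher numbers stand for weaker inhibition and lower numbers for stronger inhibition), compound 1 gives 10000 nM, compound 2 gives 10000 nM and compound 3 gives 10000 nM, so compound 3 stands level with the other two.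

Compound 4 `COc1ccc(-c2cc3c(OC)cc(OC)cc3n(CCC#N)c2=O)cc1` differs from compound 3 by one change: cyanomethyl in place of benzyloxycarbonyl on a saturated chain carbon bound to an aromatic nitrogen. In short, cyanomethyl takes the place of benzyloxycarbonyl on a saturated chain carbon bound to an aromatic nitrogen.

For the measured compounds named here, three measured steps bear on this: no change at the digits printed from compound 1 to compound 2 (within the scatter), no change at the digits printed from compound 1 to compound 3 (within the scatter) and no change at the digits printed from compound 2 to compound 3 (within the scatter). All three stay within the scatter, but each keeps the carbonyl, which this change removes, so none tests it directly. The evidence is therefore thin, and no shift beyond the scatter is expected in this assay. The estimated step is no change at the digits printed from compound 3 to compound 4 (within the scatter). Compound 4 is expected at 10000 nM, within an estimated range of 3000 nM to 12000 nM.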

Compound 4, half-maximal inhibitory concentration: 10000 nM
The estimate for compound 4 equals the measured number at the digits printed, and the stated range covers the measured number.
By their numbers in this assay, from the lowest: compounds 1, 2, 3 and 4 (each within the scatter of the next).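

In this assay, for the compounds shown here, the side chain loses its carbonyl for the first time, and the read-out shows no change at the digits printed from compound 3 to compound 4 (within the scatter), no change at the digits printed from compound 2 to compound 4 (within the scatter) and no change at the digits printed from compound 1 to compound 4 (within the scatter). On this saturated chain carbon bound to an aromatic nitrogen, then, an arm ending in a nitrile, with no carbonyl and no ring, reads level with the ester and amide arms, so the carbonyl and the benzyl ring are not needed to hold this reading. Nothing measured here offers an explanation for this level reading.

All four compounds share one value, so they do not show whether any group in this place can move it. An arm ending in an amine or a carboxylic acid, or a longer chain, remains an open case.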